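Chain extension from compound 1 to compound 3

The source may report more compounds than this note shows. Statements on the series, on what has been measured and on what is new or still open speak of the compounds shown alone.

Among the compounds with values here, compound 1 `CCCCCCCCc1ccc(NC(=O)Nc2c(C(C)C)cccc2C(C)C)cc1` gives 11 nM in an assay on isolated protein for inhibition of acyl-CoA:cholesterol acyltransferase (Oryctolagus cuniculus) (on this read-out higher numbers stand for weaker inhibition and lower numbers for stronger inhibition), the lowest of the two numbers measured so far. Compound 2 `CC(C)c1cccc(C(C)C)c1NC(=O)Nc1ccc(C(C)(C)C)cc1` gives 168 nM in this assay; the step of a 15-fold higher number from compound 1 to compound 2 (1.18 log units; beyond the scatter) is large and comes from tert-butyl in place of octyl on an aromatic carbon. Compound 3 `CCCCCCCCCCCCc1ccc(NC(=O)Nc2c(C(C)C)cccc2C(C)C)cc1` carries butyl in place of hydrogen on a saturated chain carbon, eight bonds along the chain from an aromatic carbon, so the chain on that aromatic carbon is lengthened rather than shortened. Within the data shown here, only the step from compound 1 to compound 2 bears on chain length at this place, and it runs the other way: it shows that cutting the chain back to tert-butyl weakens inhibition strongly, but gives no direct read on lengthening beyond octyl. The expectation is therefore a small change at most, within or close to the scatter, in this assay with a 1.2-fold lower number from compound 1 to compound 3 (0.09 log units; within the scatter). Compound 3 is estimated at 9 nM, with a range from 2.5 nM to 35 nM.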

Compound 3, half-maximal inhibitory concentration: 15 nM
Estimate against measurement, compound 3: 1.7-fold (0.22 log units) below; the range from low to high includes it.
By their numbers in this assay, from the lowest: compounds 1 and 3 (each within the scatter of the next); then compound 2.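

In this assay, butyl in place of hydrogen on a saturated chain carbon, eight bonds along the chain from an aromatic carbon, gives a 1.4-fold higher number from compound 1 to compound 3 (0.13 log units; within the scatter), so the added length at this position produces no change that can be told from the scatter. The earlier step covered only the cut back to tert-butyl, a 15-fold higher number from compound 1 to compound 2 (1.18 log units; beyond the scatter), and the large size of that step does not carry over to lengthening the chain beyond octyl. No supporting data bear on why compound 1 and compound 3 read alike.

Still open, from the compounds shown here alone, is whether a straight hexyl chain keeps the level of compound 1, which would separate chain length from branching in the tert-butyl step. Also open, going by these compounds, is whether this position tolerates a chain longer than that of compound 3, or a chain ending in a carboxylic acid or an amine.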